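Amide to carboxylic acid at the shared core

This account rests on a few compounds, and the source may have more. Where it says the series, first, only, none or still open, it means among the compounds named here.

Compound 2 `C=CC1=C(C(=O)NCC(C)C)C(c2ccc(OC)cc2)OC1` is the reference point for the step to compound 4. In a functional assay on A549 cells (Homo sapiens) for cytotoxicity, read by MTT assay, with a stated time of 24 h (on this read-out higher numbers stand for weaker inhibition and lower numbers for stronger inhibition), compound 2 gives only a limit, > 100000 nM. Compound 1 `C=CC1=C(C(=O)NCc2ccc(Cl)cc2)C(c2ccc(OC)cc2)OC1` likewise gives a limit in this assay, > 100000 nM. Compound 3 `C=CC1=C(C(=O)NCC(C)C)C(c2ccc(F)cc2)OC1` also gives a limit in this assay, > 100000 nM. Every value shown therefore sits at the limit of > 100000 nM in this assay, at which 3 of the 3 values shown sit, so the two measured steps, a step that the two limits leave unreadable from compound 1 to compound 2 and a step that the two limits leave unreadable from compound 2 to compound 3, are unreadable in size and direction.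

Compound 4 `C=CC1=C(C(=O)O)C(c2ccc(OC)cc2)OC1` differs from compound 2 by hydroxy in place of isobutylamino on a carbonyl carbon. Neither measured step alters the carbonyl carbon; the change from 4-chlorophenyl to isopropyl on the saturated chain carbon bound to the amide-type nitrogen and the change from methoxy to fluoro on the aromatic carbon both left the read-out at its limit. Within the data shown here, no measured step therefore bears on the step to compound 4 in a readable way. With all three values at the limit of > 100000 nM in this assay, at which 3 of the 3 values shown sit, the expectation in this assay is that compound 4 again reaches no number. The estimated step that the limit leaves unreadable from compound 2 to compound 4 is set at no change beyond the scatter. Compound 4 is estimated at 150000 nM, in the range 50000 nM to 500000 nM, and is expected most likely to be reported only as a limit.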

Compound 4, half-maximal inhibitory concentration: > 100000 nM
Compound 4: only a limit was reported; the forecaster's own chance of this, stated with the estimate: 85%; the middle value lies beyond the limit too.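

In this assay compound 4 gives > 100000 nM, which is a limit and not a number. Compound 2 also gives only a limit, so no new step can be read between compound 2 and compound 4. The compounds shown leave open which structural change, if any, would yield a numerical value in this series, as all values stand at one limit: the limit of > 100000 nM in this assay, at which 4 of the 4 values shown sit.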